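Swapping chloro for methoxy at the chain end

The source may hold more compounds than are shown below. What is called first, only, known or untested is meant among the compounds shown, and "the series" means these compounds.

Compound 2 `O=C(CN1CCN(c2cc3c(cc2F)c(=O)c(C(=O)O)cn3C2CC2)CC1)Nc1ccc(C(=O)/C=C/c2ccc(Cl)cc2)cc1` and compound 1 `O=C(CN1CCN(c2cc3c(cc2F)c(=O)c(C(=O)O)cn3C2CC2)CC1)Nc1ccc(C(=O)/C=C/c2cccc(Cl)c2)cc1` share one core and differ only in where the chloro sits. In an assay on isolated protein for inhibition of DNA topoisomerase 1 (Homo sapiens), with a stated time of 30 min, tested at 100 uM (a lower number here means a weaker effect, a higher number a stronger effect of the compound at the concentration tested), compound 1 gives 68.8%, and compound 2 gives 67.5%; the step of a number 1.3 percentage points lower from compound 1 to compound 2 (within the scatter) leaves the two indistinguishable. Compound 3 `COc1ccc(/C=C/C(=O)c2ccc(NC(=O)CN3CCN(c4cc5c(cc4F)c(=O)c(C(=O)O)cn5C4CC4)CC3)cc2)cc1` differs from compound 2 by methoxy in place of chloro on an aromatic carbon. Within the data shown here, no measured step exchanges chloro for methoxy, so the only guide is that moving the chloro changed little. For compound 3 a step of a number 3.5 percentage points lower from compound 2 to compound 3 (within the scatter) is expected, and its estimated inhibition is 64%, within 42% to 82%.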

Compound 3, a percentage reported as inhibition, at one concentration (the size of the read-out at that concentration, not a potency): 67.6%
Compound 3: middle estimate off by 3.6 percentage points, on the low side; low and high end bracket the measured number.
By their numbers in this assay, from the lowest: compounds 2, 3 and 1 (each within the scatter of the next).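

Methoxy in place of chloro on this aromatic carbon, para to a large group, gives a number 0.1 percentage points higher from compound 2 to compound 3 (within the scatter) in this assay, so a different group at this position, and not only a moved chloro, leaves the read-out unchanged. The step of a number 1.2 percentage points lower from compound 1 to compound 3 (within the scatter) shows the same when the position of the group and the group itself both differ. Nothing available explains why these groups read alike. As far as these compounds go, whether an amine or a carboxylic acid on this carbon would read the same remains open. A read-out at a single concentration also leaves open whether these compounds would show a stronger or weaker effect than one another at other concentrations.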